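Cytotoxicity notes: 2-fluorophenyl to 3-chloropropyl on the alkyne carbon

The compounds below may be only part of what the source reports. "The series", "measured", "known", "first", "only" and "open" are said of these compounds alone.

Compound 2 (`NC(=O)c1nc(C#Cc2ccccc2F)n(COCCO)n1`) carries a 2-fluorophenyl group on a triple-bonded carbon. In an ADME assay on Huh-5-2 cells (Homo sapiens) for cytotoxicity (on this read-out higher numbers stand for lower toxicity in this test and lower numbers for higher toxicity in this test), compound 2 stops at the limit of the test, > 50 ug/mL, which is a limit and not a number. Compound 1 (`NC(=O)c1nc(C#Cc2ccccc2)n(COCCO)n1`) likewise stops at a limit, giving > 50 ug/mL in this assay. The step that the two limits leave unreadable from compound 1 to compound 2 therefore cannot be read; both readings sit at the limit of > 50 ug/mL in this assay, at which 2 of the 2 values shown sit.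

Compound 3 (`NC(=O)c1nc(C#CCCCCl)n(COCCO)n1`) takes the change (3-chloropropyl in place of 2-fluorophenyl on a triple-bonded carbon). Going by the values given here, no measured step covers this exchange: the only step recorded, from a hydrogen to a fluorine on an aromatic carbon, gives no size, and both values of that pair are limits. Among the compounds with values here, every value so far sits at the limit, and nothing recorded points to compound 3 leaving it. The expected step is a step that the limit leaves unreadable from compound 2 to compound 3, none beyond the scatter, and a further limit is the most probable outcome. Compound 3 is estimated at 60 ug/mL, with a range from 30 ug/mL to 200 ug/mL.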

Compound 3, half-maximal cytotoxic concentration: > 50 ug/mL
Compound 3 gave a limit, no number; the forecaster's own chance of this, stated with the estimate: 80%; the middle value is on the limit's open side.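

No new step can be read: in this assay compound 3 stops at a limit and not a number, so its exchanges with compound 1 and compound 2 cannot be sized. The compounds shown leave open whether any group on the triple-bonded carbon gives a readable cytotoxic concentration, since every reading so far rests at one place: the limit of > 50 ug/mL in this assay, at which 3 of the 3 values shown sit.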